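The source may hold more compounds than are shown below. What is called first, only, known or untested is meant among the compounds shown, and "the series" means these compounds.

Measured so far in a functional assay on PC-3 cells (Homo sapiens) for inhibition, read by MTT assay, with a stated time of 48 h, tested at 10 uM; on this read-out higher numbers stand for more inhibition of growth at the one concentration tested and lower numbers for less inhibition of growth: compound 1 `Cc1cc(=O)c2c(O)c(CN3CC(O)CC3C(=O)O)c(O)c([C@H]3CCN(C)C[C@H]3O)c2o1` with 0%, and compound 2 `Cc1oc2c([C@H]3CCN(C)C[C@H]3O)c(O)cc(O)c2c(=O)c1C(O)c1ccc([N+](=O)[O-])cc1` with 24%.

Compound 2 stands highest of these two numbers, and its gap to compound 1 lies beyond the usual scatter. Compound 3 `Cc1oc2c([C@H]3CCN(C)C[C@H]3O)c(O)cc(O)c2c(=O)c1C(O)c1csc([N+](=O)[O-])c1` has not yet been measured. It differs from compound 2 in one place: 5-nitrothiophen-3-yl in place of 4-nitrophenyl on a saturated chain carbon bound to an aromatic carbon and an oxygen on a saturated carbon. Within the data shown here, no measured pair shows this kind of exchange, so no firm direction can be read from the data; only a small step is expected, not beyond the scatter: a number 2 percentage points lower from compound 2 to compound 3 (within the scatter). Compound 3 is accordingly estimated at 22%, within a range from 5% to 45%.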

Compound 3, percent growth inhibition at one concentration: 0%
Estimate against measurement, compound 3: 22 percentage points above; the whole stated range lies above it.
By their numbers in this assay, from the lowest: compounds 1 and 3 (each within the scatter of the next); then compound 2.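

In this assay, the exchange at this saturated chain carbon gives a number 24 percentage points lower from compound 2 to compound 3 (beyond the scatter). The position therefore does not treat these two nitro-bearing aromatic rings alike: 5-nitrothiophen-3-yl does not keep the growth inhibition seen with 4-nitrophenyl, a difference the earlier pair could not show. Nothing measured here explains this drop.

The compounds shown leave open whether the nitro group is needed at all, or only the ring that carries it. A plain phenyl or a 4-aminophenyl group on this carbon would speak to that question.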